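The source may report more compounds than this note shows. Statements on the series, on what has been measured and on what is new or still open speak of the compounds shown alone.

Working notes on the sulfonyl amine series, read in an in vitro ADME assay on microsomes from liver (Homo sapiens) for metabolic stability, read by LC-MS, tested at 1 uM; on this read-out higher numbers stand for fast clearance and lower numbers for slow clearance. Compound 1 `Cc1ccc(S(=O)(=O)N(C)C(C)C)cc1C#Cc1cc(Cl)ccc1OCC(=O)O` gives < 10 mL.min-1.g-1, which is a limit of the assay and not a number. Among the measured compounds shown here, compound 2 `Cc1ccc(S(=O)(=O)N2CCCCC2C)cc1C#Cc1cc(Cl)ccc1OCC(=O)O` gives 89 mL.min-1.g-1, the only true number so far in this assay.

Compound 3 `Cc1ccc(S(=O)(=O)N(C)CC(C)C)cc1C#Cc1cc(Cl)ccc1OCC(=O)O` is still unmeasured. The change leading to it is isobutyl(methyl)amino in place of 2-methylpiperidin-1-yl on a sulfonyl sulfur, so the ring leaves and an open chain enters.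

For the measured compounds named here, one measured step bears on this. an at least 8.9-fold higher number from compound 1 to compound 2 (0.94 log units; beyond the scatter) lies beyond the scatter and went the other way, with 2-methylpiperidin-1-yl replacing isopropyl(methyl)amino at the same place. Its size is only a lower bound. It is a single step, and isobutyl(methyl)amino is not the same group as isopropyl(methyl)amino, so only a partial reversal of an at least 8.9-fold higher number from compound 1 to compound 2 (0.94 log units; beyond the scatter) is expected, not a full return to the reading of compound 1.

The expected step is a 3.6-fold lower number from compound 2 to compound 3 (0.55 log units; beyond the scatter), toward a lower number and beyond the scatter. For compound 3 the estimated value is 25 mL.min-1.g-1, with an expected range of 9 mL.min-1.g-1 to 70 mL.min-1.g-1.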

Compound 3, intrinsic clearance in microsomes: 79 mL.min-1.g-1
The estimate for compound 3 lay 3.2-fold (0.50 log units) below the measured number, and the stated range ends below it.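

In this assay, the ring of 2-methylpiperidin-1-yl gives way to the open chain of isobutyl(methyl)amino with a 1.1-fold lower number from compound 2 to compound 3 (0.05 log units; within the scatter), so at this place on the sulfonyl sulfur, compound 2 and compound 3 read alike whether the group is cyclic or not. The large gap instead appears between the two open-chain compounds, where isobutyl in place of isopropyl on a sulfonamide nitrogen gives an at least 7.9-fold higher number from compound 1 to compound 3 (0.89 log units; beyond the scatter), which shows that having an open chain at this place does not by itself set the reading in this assay. The size of that step is only a lower bound because compound 1 reads at a limit of the assay and not a number: the limit of < 10 mL.min-1.g-1 in this assay, at which 1 of the 3 values shown sits.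

Among these three compounds, only compound 1 stands apart, so a single group, isopropyl(methyl)amino, carries the whole contrast, and whether it holds for other groups on the sulfonamide nitrogen remains open. A tert-butyl group, a longer chain such as n-pentyl, or a ring with a second hetero atom such as morpholin-4-yl would test how far that contrast extends.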